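Oxime ether series: extending the methoxy to propoxy

A few compounds are considered here, and "the series" means these few. Any claim that something is new, unique, unknown or untested is made for them only; others in the source may bear on it.

Compound 1 `CO/N=C/c1cc(OC)c2c(c1OC)C(=O)C=CC2=O` carries a methoxy on the oxime; in a functional assay on L1210 cells (Mus musculus) for antiproliferative activity (a lower number here means that less compound is needed, a higher number that more compound is needed for the effect), compound 1 gives 0.109 ug/mL, the lowest of the three numbers, though its gaps to compound 3 and compound 2 are within the scatter. Compound 2 `CCCCCC/C(=N\OC)c1cc(OC)c2c(c1OC)C(=O)C=CC2=O` gives 0.192 ug/mL, and compound 3 `CCCCCC/C(=N\OCCC)c1cc(OC)c2c(c1OC)C(=O)C=CC2=O` gives 0.166 ug/mL. Compound 4 `CCCO/N=C/c1cc(OC)c2c(c1OC)C(=O)C=CC2=O` differs from compound 1 by ethyl in place of hydrogen on a saturated chain carbon bound to an oxygen on an unsaturated carbon. Going by the values given here, the one measured step of the same kind, a 1.2-fold lower number from compound 2 to compound 3 (0.06 log units; within the scatter), is the only guide, and it did not move the number beyond the scatter. For compound 4 the expectation is therefore a step of a 1.1-fold lower number from compound 1 to compound 4 (0.04 log units; within the scatter), that is no change beyond the scatter. Compound 4 is estimated at 0.1 ug/mL, in the range 0.05 ug/mL to 0.2 ug/mL.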

Compound 4, concentration for half-maximal effect: 0.107 ug/mL
For compound 4 the middle estimate is 1.1-fold (0.03 log units) below the measured one, and the stated range covers the measured number.
By their numbers in this assay, from the lowest: compounds 4, 1, 3 and 2 (each within the scatter of the next).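

Methoxy to propoxy, at a saturated chain carbon bound to an oxygen on an unsaturated carbon, again leaves the number in this assay unmoved, with a 1.0-fold lower number from compound 1 to compound 4 (0.01 log units; within the scatter). This change was previously read on one core only; it now stands on two, and the two steps agree: the same change on two cores in this assay, a 1.2-fold lower number (0.06 log units; within the scatter) from compound 2 to compound 3 and a 1.0-fold lower number (0.01 log units; within the scatter) from compound 1 to compound 4, 1.1-fold (0.06 log units) apart, within the scatter of two such steps

The steps shown span only methyl to propyl. On these data alone, whether the number also holds with a longer chain such as octyl, or with a propyl chain ending in an amine or a carboxylic acid, remains open.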